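Taking the Benzyl off Compound 3

A few compounds are considered here, and "the series" means these few. Any claim that something is new, unique, unknown or untested is made for them only; others in the source may bear on it.

In a functional assay on HT-1080 cells (Homo sapiens) for antiproliferative activity, read by MTT assay, with a stated time of 72 h (a higher number here means a weaker inhibitor, a lower number a stronger inhibitor), compound 2 `COc1ccc(-c2ccsc2-c2cc(OC)c(OC)c(OC)c2)cc1` reads 3620 nM as a measured number. Compound 1 `CCOC(=O)c1cc(-c2ccc(OC)c(O)c2)c(-c2cc(OC)c(OC)c(OC)c2)s1` also bears a hydroxy and reads 82600 nM in this assay as well, which keeps any expectation for a hydroxy compound wide. Compound 3 `COc1ccc(-c2ccsc2-c2cc(OC)c(OC)c(OC)c2)cc1OCc1ccccc1` reads > 100000 nM which is a limit and not a number, so its place on the scale is known only from that limit. The change to compound 4 `COc1ccc(-c2ccsc2-c2cc(OC)c(OC)c(OC)c2)cc1O` is hydrogen in place of benzyl on an oxygen on an aromatic ring, benzyloxy to hydroxy hydrogen in place of benzyl on an oxygen on an aromatic ring and nothing else differs. Going by the values given here, the one measured step that bears on it is an at least 27-fold higher number from compound 2 to compound 3 (1.44 log units; beyond the scatter) with benzyloxy in place of hydrogen on an aromatic carbon, so a large step towards a lower number in this assay is expected. The expected size is an at least 40-fold lower number from compound 3 to compound 4 (1.60 log units; beyond the scatter) in this estimate. Compound 4 is expected to read 2500 nM within an estimated range of 200 nM to 30000 nM when measured.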

Compound 4, half-maximal inhibitory concentration: 2120 nM
Beside the measured number, compound 4's estimate is 1.2-fold (0.07 log units) above it, within the range that was stated.
By their numbers in this assay, from the lowest: compounds 4 and 2 (each within the scatter of the next); then compound 1. At a limit, above all of these: compound 3.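

In this assay, hydrogen in place of benzyl on the oxygen gives an at least 47-fold lower number from compound 3 to compound 4 (1.67 log units; beyond the scatter), a step that rests on a limit for compound 3 and not on a number: the limit of > 100000 nM in this assay, at which 1 of the 4 values shown sits.

The added hydroxy leaves the reading within the scatter, with a 1.7-fold lower number from compound 2 to compound 4 (0.23 log units; within the scatter), so the large loss in compound 3 goes with the benzyl and not with the oxygen itself. Hydrogen in place of ethoxycarbonyl on an aromatic carbon gives a 39-fold lower number from compound 1 to compound 4 (1.59 log units; beyond the scatter), so the weak reading of compound 1 goes with the ethoxycarbonyl and not with its hydroxy.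

The compounds shown leave open how a group on this oxygen smaller than benzyl, such as ethyl, or a longer chain ending in an amine, would read. They also leave open whether a carboxylic acid or an amide in place of the ethoxycarbonyl would read as weakly as compound 1.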